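Replacing a Phenylethyl Arm with an Aminopropyl Chain

This account rests on a few compounds, and the source may have more. Where it says the series, first, only, none or still open, it means among the compounds named here.

Measured compounds:
- Compound 1, `O=C(NCc1ccc(F)cc1)c1nc(Br)c2cccnc2c1NCCCNc1c(C(=O)NCc2ccc(F)cc2)nc(Br)c2cccnc12`: "not determined" (no result reported) in a functional assay on MCF7 cells (Homo sapiens) for cytotoxicity, read by MTT assay, with a stated time of 72 h; on this read-out higher numbers stand for weaker inhibition and lower numbers for stronger inhibition
- Compound 2, `C[C@@H](Nc1c(C(=O)NCc2ccc(F)cc2)nc(Br)c2cccnc12)c1ccccc1`: "not determined" (no result reported) in this assay
- Compound 3, `CN(C)c1ccc(CNC(=O)c2nc(Br)c3cccnc3c2N[C@H]2CC[C@H](N)CC2)cc1`: 5000 nM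

Going by the values given here, only one of the three compounds tested in this assay has a number. Compound 1 and compound 2 were not determined, so compound 2 stands without any value; compound 3, which carries a different amine on the shared core, gives 5000 nM in this assay, a weak result.

The compound not yet tested is compound 4, `NCCCNc1c(C(=O)NCc2ccc(F)cc2)nc(Br)c2cccnc12`. It differs from compound 2 in one place: 3-aminopropyl in place of 1-phenylethyl on a nitrogen on an aromatic ring. Cut one bond further out, the change reads (1-phenylethyl)amino to (3-aminopropyl)amino.

Since compound 2 has no number in this assay, the step from compound 2 to compound 4 cannot be given a size or direction from the data. Among the compounds with values here, the only anchor is compound 3, which shares the core and is weak. Compound 4 is therefore expected to be weak as well, with a fair chance that this assay returns only a limit. Compound 4 is estimated at 8000 nM in this assay, within a range of 2000 nM to 30000 nM.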

Compound 4, half-maximal inhibitory concentration: 6000 nM
Estimate against measurement, compound 4: 1.3-fold (0.12 log units) above; the range from low to high includes it.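

In this assay, going by these compounds alone, compound 2 has no single number, so no step from it to compound 4 can be read. Going by these compounds, whether 3-aminopropyl in place of 1-phenylethyl shifts the result in either direction stays open, and no evidence bears on this result.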